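The compounds below may be only part of what the source reports. "The series", "measured", "known", "first", "only" and "open" are said of these compounds alone.

In a functional assay on the whole organism for inhibition, with Rattus norvegicus as the target, read by ELISA, with stated times of 30 min and 6 h, at a dose of 30 mg/kg by the oral route (a higher number here means more inhibition at the dose given (going by the name of the read-out), a lower number less inhibition), compound 3 `Cc1ccc(-c2cc3c(=N)sc(=S)[nH]c3n2-c2ccccc2)cc1` gives 0%. This stands level with compound 1 `N=c1sc(=S)[nH]c2c1cc(-c1ccccc1)n2-c1ccccc1`, which gives 0%, and these two are together the lowest of the three numbers measured; compound 2 `N=c1sc(=S)[nH]c2c1cc(-c1ccc(Cl)cc1)n2-c1ccccc1` gives 2%. Every measured step stays within the scatter: a number 2 percentage points higher from compound 1 to compound 2 (within the scatter), no change at the digits printed from compound 1 to compound 3 (within the scatter) and a number 2 percentage points lower from compound 2 to compound 3 (within the scatter).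

Compound 4 `N=c1sc(=S)[nH]c2c1cc(-c1ccc(Br)cc1)n2-c1ccccc1` is made from compound 3 by one change: bromo in place of methyl on an aromatic carbon. The three measured steps all swap a small group at this same aromatic carbon, and none of them moved this assay beyond the scatter. On that basis the step to compound 4 is expected to be a number 1 percentage points higher from compound 3 to compound 4 (within the scatter). Compound 4 is therefore estimated at 1%, within a range of 0% to 8%.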

Compound 4, a percentage reported as inhibition, in the whole organism at one dose (the size of the read-out at that dose, not a potency): 44%
The estimate for compound 4 lay 43 percentage points below the measured number; the whole stated range lies below it.
By their numbers in this assay, from the lowest: compounds 1, 3 and 2 (each within the scatter of the next); then compound 4.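

Bromo on this aromatic carbon gives a number 44 percentage points higher from compound 3 to compound 4 (beyond the scatter) in this assay, along with a number 42 percentage points higher from compound 2 to compound 4 (beyond the scatter) and a number 44 percentage points higher from compound 1 to compound 4 (beyond the scatter) in the same read-out. This position can therefore matter greatly, and the outcome depends on the exact group: hydrogen, methyl and chloro stay within the scatter of one another, while bromo stands well apart from all three. No measurement here explains why bromo separates from chloro and methyl.

As far as these compounds go, whether iodo, an amine or a carboxylic acid at this carbon would behave like bromo remains open. So does whether bromo keeps this effect when the other phenyl ring carries a substituent.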